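Replacing an Amide by a Cyclopentyl Group on a Shared Core

This account rests on a few compounds, and the source may have more. Where it says the series, first, only, none or still open, it means among the compounds named here.

Compound 1 `Nc1ncc(-c2cccc(Cl)c2)c(-c2ccccc2)n1` is a limit case: in an assay on CHO cells for displacement of a labelled ligand from adenosine receptor A1 (Homo sapiens), read by scintillation counting, with a stated time of 1 h, tested at 1 uM (a lower number here means less inhibition, a higher number more inhibition at the concentration tested (going by the name of the read-out)), compound 1 gives > 80%, a limit of the assay rather than a number. Compound 2 `O=C(Nc1ncc(-c2cccc(Cl)c2)c(-c2ccccc2)n1)C1CCC1` gives 52% in this assay, the only plain number shown. Among the measured compounds shown here, the step of a number at least 28 percentage points lower from compound 1 to compound 2 (beyond the scatter) is the sole measured step, and it concerns the same nitrogen. Compound 3 `Clc1cccc(-c2cnc(NC3CCCC3)nc2-c2ccccc2)c1` differs from compound 2 by cyclopentyl in place of cyclobutylcarbonyl on a nitrogen on an aromatic ring. For the measured compounds named here, no measured step covers this exchange, so the expected step of a number 13 percentage points higher from compound 2 to compound 3 (beyond the scatter) is a guess of modest size upward. Compound 3 is estimated at 65%, between 35% and 88%.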

Compound 3, a percentage reported as inhibition, at one concentration (the size of the read-out at that concentration, not a potency): > 80%
Compound 3: no number, only a limit; the forecaster's own chance of this, stated with the estimate: 15%; middle value at least 15 percentage points away from the limit.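

Cyclopentyl in place of cyclobutylcarbonyl on this nitrogen gives a number at least 28 percentage points higher from compound 2 to compound 3 (beyond the scatter) in this assay. A group on this nitrogen therefore does not always lower inhibition, as the earlier step alone might have suggested. The step from compound 1 to compound 3 cannot be read, because both values are limits: the limit of > 80% in this assay, at which 2 of the 3 values shown sit.

The exchange changes both the carbonyl and the ring size, so the two effects stay unseparated. A cyclobutyl or cyclopentylcarbonyl group on this nitrogen could tell them apart.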